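This account rests on a few compounds, and the source may have more. Where it says the series, first, only, none or still open, it means among the compounds named here.

Measured compounds in an ADME assay on Huh-5-2 cells (Homo sapiens) for cytotoxicity, read by WST assay, with a stated time of 3 days; a lower number here means that less compound is tolerated, a higher number that more compound is tolerated:

compound 1, `N#Cc1cccc(COc2c(-c3ccccc3)oc3cc(O)cc(O)c3c2=O)c1`: 21000 nM
compound 2, `O=c1c(OCc2cccc([N+](=O)[O-])c2)c(-c2ccccc2)oc2cc(O)cc(O)c12`: 31000 nM

Compound 2 gives the highest of the two numbers in this assay, but its nearest neighbour is compound 1, and the step of a 1.5-fold higher number from compound 1 to compound 2 (0.17 log units; within the scatter) means the two cannot be told apart. Compound 3, `O=c1c(OCc2ccc(Cl)cc2)c(-c2ccccc2)oc2cc(O)cc(O)c12`, has not yet been measured in this assay. It differs from compound 2 by 4-chlorophenyl in place of 3-nitrophenyl on a saturated chain carbon bound to an oxygen on an aromatic ring. Going by the values given here, the one measured step that bears on this change is the one from compound 1 to compound 2, which also exchanged a group on the benzyl ring bound to the oxygen of the shared core; that step, a 1.5-fold higher number from compound 1 to compound 2 (0.17 log units; within the scatter), stayed within the scatter. Among the compounds with values here, no measured pair shows a change from a nitrophenyl to a chlorophenyl, so the only guide is that a swap of one substituent on this benzyl ring has so far not moved the number beyond the scatter. Compound 3 is therefore expected to land close to compound 2, with a step of a 1.1-fold lower number from compound 2 to compound 3 (0.06 log units; within the scatter) that is not expected to exceed the scatter. The estimate for compound 3 in this assay is 27000 nM, with a range from 11000 nM to 65000 nM.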

Compound 3, half-maximal cytotoxic concentration: 36000 nM
Compound 3: the middle estimate sits 1.3-fold (0.12 log units) below what was measured, and the stated range covers the measured number.
By their numbers in this assay, from the lowest: compounds 1, 2 and 3 (each within the scatter of the next).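

In this assay, the exchange at this position now reaches beyond swapping one 3-substituted phenyl for another: 4-chlorophenyl replaces 3-nitrophenyl with a 1.2-fold higher number from compound 2 to compound 3 (0.06 log units; within the scatter), and it replaces 3-cyanophenyl with a 1.7-fold higher number from compound 1 to compound 3 (0.23 log units; within the scatter). The exchange from 3-nitrophenyl to 4-chlorophenyl changes both the substituent and its name-given ring position, and removes the hydrogen-bond acceptors counted for the nitro-bearing group, yet neither step leaves the scatter, so the three compounds cannot be ranked and this position shows no measurable sensitivity across these groups. No available evidence accounts for this lack of separation, which therefore remains an observation with no established cause.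

The compounds shown leave open whether an amine or a carboxylic acid on the benzyl ring, or a longer chain between the ring and the oxygen, would move the number beyond the scatter. They also leave open how changes elsewhere on the shared core, such as replacing its hydroxyl groups with methoxy groups, would behave, as all three compounds keep that core unchanged.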